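Swapping the ether for a cyclic amine on the shared core

A few compounds are considered here, and "the series" means these few. Any claim that something is new, unique, unknown or untested is made for them only; others in the source may bear on it.

Of the compounds shown here, three built on one core have been measured in a functional assay on KB cells (Homo sapiens) for inhibition, read by sulforhodamine B assay, with a stated time of 48 h; on this read-out lower numbers stand for stronger inhibition of growth and higher numbers for weaker inhibition of growth. Compound 1 `COc1ccc2c(c1)NC(=O)CN2c1nc(Nc2cccc(C#N)c2)nc2ccccc12` gives 61.5 nM, compound 2 `COc1ccc2c(c1)NC(=O)CN2c1nc(OCC2CC2)nc2ccccc12` gives 14.2 nM, and compound 3 `COc1ccc2c(c1)NC(=O)CN2c1nc(Nc2ccc(C#N)cc2)nc2ccccc12` gives 5.39 nM. Compound 2 thus holds the second highest number of the three: it sits a 2.6-fold lower number from compound 2 to compound 3 (0.42 log units; beyond the scatter), while a 4.3-fold lower number from compound 1 to compound 2 (0.64 log units; beyond the scatter).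

Compound 4 `COc1ccc2c(c1)NC(=O)CN2c1nc(N2CCCC2)nc2ccccc12` differs from compound 2 in one place: pyrrolidin-1-yl in place of cyclopropylmethoxy on an aromatic carbon. Among the measured compounds shown here, two measured steps touch the same position. In one, a 4.3-fold lower number from compound 1 to compound 2 (0.64 log units; beyond the scatter); in the other, a 2.6-fold lower number from compound 2 to compound 3 (0.42 log units; beyond the scatter). For the measured compounds named here, both are modest, and neither involves pyrrolidin-1-yl, so they show only that exchanges at this aromatic carbon have so far shifted the number by modest amounts in either direction. The direct step from compound 2 to compound 4 is therefore expected to be modest at most, with no firm direction, and the writer leans toward a number close to that of compound 2, expecting a 1.4-fold higher number from compound 2 to compound 4 (0.15 log units; within the scatter). Compound 4 is estimated at 20 nM, within a range from 5 nM to 80 nM.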

Compound 4, concentration for 50% growth inhibition: 33.2 nM
The estimate for compound 4 lay 1.7-fold (0.22 log units) below the measured number; the measured number falls inside the stated range.
By their numbers in this assay, from the lowest: compound 3; then compound 2; then compounds 4 and 1 (each within the scatter of the next).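

In this assay, the exchange of cyclopropylmethoxy for pyrrolidin-1-yl, at the aromatic carbon between two ring nitrogen atoms, keeps the count of heavy atoms and still gives a 2.3-fold higher number from compound 2 to compound 4 (0.37 log units; beyond the scatter), so a ring amine does not simply stand in for this ether. The (4-cyanophenyl)amino group of compound 3 stays clearly ahead of the ring amine, with a 6.2-fold higher number from compound 3 to compound 4 (0.79 log units; beyond the scatter) as the step away from it. The (3-cyanophenyl)amino group of compound 1 cannot be told apart from pyrrolidin-1-yl, the step being a 1.9-fold lower number from compound 1 to compound 4 (0.27 log units; within the scatter), so only one of the two cyanophenyl amines is separated from it. No measurement given here explains these differences.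

As far as these compounds go, it remains open whether piperidin-1-yl, morpholin-4-yl or an open-chain amine such as dimethylamino would behave like pyrrolidin-1-yl at this carbon. A longer ether chain in place of cyclopropylmethoxy is equally untested among the compounds shown.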